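From isobutoxy to trifluoromethoxy: a step behind a limit

The source may report more compounds than this note shows. Statements on the series, on what has been measured and on what is new or still open speak of the compounds shown alone.

In an ADME assay on BJ cells (Homo sapiens) for cytotoxicity, read by luminescence, with a stated time of 72 h (a higher number here means that more compound is needed for the effect, a lower number that less compound is needed), compound 1 `CCCCOc1cccc(-c2[nH]c3cc(OC)ccc3c(=O)c2C(=O)OCC)c1` gives > 21500 nM as a limit and not a number. Compound 2 `CCOC(=O)c1c(-c2cccc(OCC(C)C)c2)[nH]c2cc(OC)ccc2c1=O` gives > 21500 nM as a limit too. All that is known so far is the limit of > 21500 nM in this assay, at which 2 of the 2 values shown sit, and no true number for either compound.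

Compound 3 `CCOC(=O)c1c(-c2cccc(OC(F)(F)F)c2)[nH]c2cc(OC)ccc2c1=O` differs from compound 2 by trifluoromethyl in place of isobutyl on an oxygen on an aromatic ring in the form of trifluoromethyl in place of isobutyl on an oxygen on an aromatic ring. Within the data shown here, the only measured step that bears on this is a step that the two limits leave unreadable from compound 1 to compound 2 for a smaller change on that oxygen-bound chain, and it offers no size to carry over. In this assay the expected result is a step that the limit leaves unreadable from compound 2 to compound 3 with no direction foreseen. For compound 3 the estimated value is 25000 nM within an expected range of 12000 nM to 50000 nM and quite possibly only a limit again.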

Compound 3, half-maximal effective concentration: > 21500 nM
Compound 3: only a limit was reported (the forecaster's own chance of this, stated with the estimate: 75%); the middle value does not contradict the limit.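

No step can be read between compound 1, compound 2 and compound 3 in this assay, because each gives only a limit and not a true number: the limit of > 21500 nM in this assay, at which 3 of the 3 values shown sit.

The compounds shown leave open how much of each is needed for the effect, and whether changing isobutoxy to trifluoromethoxy alters that amount.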